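The source may hold more compounds than are shown below. What is called first, only, known or untested is meant among the compounds shown, and "the series" means these compounds.

Measured compounds:
Compound 1 `Cc1cn([C@H]2C[C@H](CC3=CC(=O)C(=O)C=C3)[C@@H](CO[Si](C)(C)C(C)(C)C)O2)c(=O)[nH]c1=O`: no result reported
Compound 2 `COc1ccc(C2([C@H]3C[C@H](n4cc(C)c(=O)[nH]c4=O)O[C@@H]3CO[Si](C)(C)C(C)(C)C)SCCCS2)cc1OC`: 4680 nM

In a functional assay on A549 cells (Homo sapiens) for inhibition, read by sulforhodamine B assay, with a stated time of 48 h (on this read-out higher numbers stand for weaker inhibition of growth and lower numbers for stronger inhibition of growth), compound 2 gives 4680 nM. Going by the values given here, this is the only number available, so it cannot be ranked against compound 1. Compound 3 `COc1ccc(C2([C@H]3C[C@@H](n4cc(C)c(=O)[nH]c4=O)O[C@@H]3CO[Si](C)(C)C(C)(C)C)SCCCS2)cc1OC` has the same atoms and bonds as compound 2 and differs only in configuration as drawn: the two compounds have the same atoms and bonds and differ only in configuration as drawn: 1 of 3 stereo elements differ; a stereocentre at a saturated ring carbon is drawn R in compound 2 and S in compound 3. Among the compounds with values here, no measured step shows what such a change does in this assay. The estimated change, a 1.3-fold higher number from compound 2 to compound 3 (0.11 log units; within the scatter), is therefore expected to stay within the usual scatter, with no firm direction. For compound 3 the expected value is 6000 nM, with an estimated range from 2000 nM to 20000 nM.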

Compound 3, concentration for 50% growth inhibition: 5370 nM
For compound 3 the middle estimate is 1.1-fold (0.05 log units) above the measured one, and the stated range covers the measured number.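

In this assay, going by these compounds alone, the inversion at this saturated ring carbon gives a 1.1-fold higher number from compound 2 to compound 3 (0.06 log units; within the scatter), the only measured step at this stereocentre. Drawing the centre S rather than R therefore has no effect here that can be told from the scatter, at the micromolar level of this pair. The comparison isolates this one centre: the fact that compounds 2 and 3 differ only in the configuration as drawn. The compounds shown leave open whether configuration at this carbon would matter as little with a free hydroxyl in place of the silyl ether, or with an amine there.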